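The compounds below may be only part of what the source reports. "The series", "measured", "known", "first", "only" and "open" are said of these compounds alone.

Measured so far in a physicochemical assay for lipophilicity, measured as octanol-water partition, at pH 7.4; on this read-out lower numbers stand for lower lipophilicity and higher numbers for higher lipophilicity:
compound 1 `CC(C)c1noc(N2CCC(Oc3cc(N4CCc5cc(C6CCCCC6=O)ccc54)ncn3)CC2)n1`: 4.7
compound 2 `CC(C)c1noc(N2CCC(Oc3cc(N4CCc5cc(N6CCCNS6(=O)=O)ccc54)ncn3)CC2)n1`: 3.2
compound 3 `CC(=O)N(C)c1ccc2c(c1)CCN2c1cc(OC2CCN(c3nc(C(C)C)no3)CC2)ncn1`: 3.7

Among these three numbers, compound 3, at 3.7, is the second highest and lies closer to compound 2 than to compound 1.

The next compound, compound 4 `CC(C)c1noc(N2CCC(Oc3cc(N4CCc5cc(S(=O)(=O)CCO)ccc54)ncn3)CC2)n1`, has not been measured yet. It keeps the shared core of compound 3 and changes one group: (2-hydroxyethyl)sulfonyl in place of acetyl(methyl)amino on an aromatic carbon.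

Going by the values given here, three measured steps bear on this change, since each also swaps a group on an aromatic carbon. The first is modest: a number 1.00 log units lower from compound 1 to compound 3 (beyond the scatter). The second is large: a number 1.50 log units lower from compound 1 to compound 2 (beyond the scatter). The third is modest again: a number 0.50 log units higher from compound 2 to compound 3 (beyond the scatter). All three lie beyond the scatter. Among the compounds with values here, compound 2, the only measured compound with sulfur in this group, stands at 3.2, and the expectation leans on that value. Within the data shown here, no measured compound carries the (2-hydroxyethyl)sulfonyl group, and the range therefore stays wide.

In this assay a modest downward step is expected: a number 0.50 log units lower from compound 3 to compound 4 (beyond the scatter). For compound 4 the estimated value is 3.2, with an expected range from 2.7 to 3.7.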

Compound 4, distribution coefficient: 2.7
For compound 4 the middle estimate is 0.50 log units above the measured one; the range from low to high includes it.
By their numbers in this assay, from the lowest: compound 4; then compound 2; then compound 3; then compound 1.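

On the aromatic carbon that carries the changing group, in this assay, putting (2-hydroxyethyl)sulfonyl in place of acetyl(methyl)amino gives a clear drop (a number 1.00 log units lower from compound 3 to compound 4 (beyond the scatter)), and compound 4 now has the lowest number of the four compounds. Going by these compounds alone, it also falls below the only other compound with sulfur in this group (a number 0.50 log units lower from compound 2 to compound 4 (beyond the scatter)), and its distance from the 2-oxocyclohexyl compound (a number 2.00 log units lower from compound 1 to compound 4 (beyond the scatter)) exceeds the widest step seen earlier (a number 1.50 log units lower from compound 1 to compound 2 (beyond the scatter)), so this one position spans more of the scale than the first three compounds showed. The two groups containing sulfur now hold the two lowest numbers and no compound here goes against that, but nothing measured explains the order.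

The compounds shown do not separate the sulfonyl part of the new group from its hydroxyethyl chain, so what a plain methylsulfonyl group or a longer chain ending in hydroxyl would give stays open. As far as these compounds go, whether an amine or a carboxylic acid on this aromatic carbon would reach lower still also remains unknown.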